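Cytotoxicity Outlook for a Chlorophenyl Cyclopropyl Amide

The compounds below may be only part of what the source reports. "The series", "measured", "known", "first", "only" and "open" are said of these compounds alone.

Compound 2 `Cc1cc(C)cc(S(=O)(=O)c2c(C(=O)NC(C)C(=O)NCc3ccncc3)[nH]c3ccc(Cl)cc23)c1` gives 19500 nM in an ADME assay on MT4 cells (Homo sapiens) for cytotoxicity, read by MTT assay (on this read-out higher numbers stand for lower toxicity in this test and lower numbers for higher toxicity in this test), the lowest of the two numbers shown; compound 1 `Cc1cc(C)cc(S(=O)(=O)c2c(C(=O)NC(C)C(=O)NCc3ccco3)[nH]c3ccc(Cl)cc23)c1` gives 24200 nM, and the step of a 1.2-fold lower number from compound 1 to compound 2 (0.09 log units; within the scatter) lies within the scatter. Compound 3 `Cc1cc(C)cc(S(=O)(=O)c2c(C(=O)NC(c3ccc(Cl)cc3)C3CC3)[nH]c3ccc(Cl)cc23)c1` carries a group of 11 heavy atoms (10 carbon, 1 chlorine; one three-membered non-aromatic ring of carbon only, one six-membered aromatic ring of carbon only) in place of a group of 12 heavy atoms (9 carbon, 2 nitrogen, 1 oxygen; one six-membered aromatic ring with 1 hetero atom), on an amide-type nitrogen. Within the data shown here, the only measured step touches a different, smaller part of the chain and stayed within the scatter, so it bears only weakly on this larger exchange; no measured step addresses a change of this kind. The expected step is a 1.1-fold lower number from compound 2 to compound 3 (0.06 log units; within the scatter), not clearly beyond the scatter. Compound 3 is estimated at 17000 nM in this assay, with a range from 7000 nM to 40000 nM.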

Compound 3, half-maximal cytotoxic concentration: > 47300 nM
Compound 3 ended at the assay's limit; the forecaster's own chance of this, stated with the estimate: 10%; middle value at least 2.7-fold (0.44 log units) away from the limit.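

In this assay compound 3 stands at a limit and not at a number: the limit of > 47300 nM in this assay, at which 1 of the 3 values shown sits. Replacing the whole group on the amide-type nitrogen gives an at least 2.4-fold higher number from compound 2 to compound 3 (0.38 log units; beyond the scatter), a shift towards lower toxicity in this test that the earlier exchange of one aromatic ring did not show. The comparison with the furan-bearing compound gives an at least 1.9-fold higher number from compound 1 to compound 3 (0.29 log units; that floor lies within the scatter), so it alone does not separate the two.

The compounds shown leave open which of the two rings in the entering group goes with this step. They also leave open how a carboxylic acid or an amine in that place would read.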